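Where Chlorine Gives Way to a Larger Chain Terminus

A few compounds are considered here, and "the series" means these few. Any claim that something is new, unique, unknown or untested is made for them only; others in the source may bear on it.

Compound 1, `Cn1c(=O)c2[nH]c(Cc3ccc(OCCCn4ccnc4)cc3)nc2n(C)c1=O`, gives in an assay on CHO cells for displacement of a labelled ligand from adenosine receptor A1 (Homo sapiens), read by scintillation counting, with a stated time of 3 h (a lower number here means a stronger inhibitor, a higher number a weaker inhibitor), the value > 30 nM, a limit of the assay rather than a number.
Compound 2, `Cn1c(=O)c2[nH]c(-c3ccc(OCCCCl)cc3)nc2n(C)c1=O`, gives > 10 nM, again a limit.
Compound 3, `Cn1c(=O)c2[nH]c(Cc3ccc(OCCCCl)cc3)nc2n(C)c1=O`, gives > 30 nM, also a limit.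

Within the data shown here, compound 3 stands at the limit of > 30 nM in this assay, at which 2 of the 3 values shown sit, and compound 2 at the limit of > 10 nM in this assay, at which 1 of the 3 values shown sits; since every value shown is a limit, no compound can be placed above or below another. Among the measured compounds shown here, the only single-point step, a step that the two limits leave unreadable from compound 1 to compound 3, is unreadable for the same reason. Compound 4, `Cn1c(=O)c2[nH]c(Cc3ccc(OCCCN4CCC5(CC4)OCCO5)cc3)nc2n(C)c1=O`, differs from compound 3 by a group of 10 heavy atoms (7 carbon, 1 nitrogen, 2 oxygen; one five-membered non-aromatic ring with 2 hetero atoms, one six-membered non-aromatic ring with 1 hetero atom) in place of one chlorine atom, on a saturated chain carbon, three bonds along the chain from an oxygen on an aromatic ring. For the measured compounds named here, no readable measured step bears on this change, and the one step at that chain position tells nothing of its size. The expectation therefore rests on the limit of compound 3 alone, and compound 4 is expected to show no step beyond the scatter, the estimated step being a step that the limit leaves unreadable from compound 3 to compound 4. Compound 4 is accordingly estimated at 300 nM, with a range from 30 nM to 3000 nM, and most likely reported only as a limit.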

Compound 4, inhibition constant: > 30 nM
Compound 4: a limit, no number; the forecaster's own chance of this, stated with the estimate: 70%; the middle value does not contradict the limit.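

Compound 4 gives > 30 nM in this assay, again a limit and not a number, and the steps to it from compound 1 and from compound 3 cannot be read. The compounds shown leave open how strong an inhibitor any of them is, and whether the group ending the chain matters at all.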